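The compounds below may be only part of what the source reports. "The series", "measured", "known", "first", "only" and "open" are said of these compounds alone.

In a functional assay on Z-138 cells (Homo sapiens) for inhibition, read by luminescence and CellTiter-Glo, with a stated time of 72 h (on this read-out lower numbers stand for stronger inhibition and higher numbers for weaker inhibition), the measured compounds are: compound 1 `C=CC(=O)N1CCCC(n2nc(-c3ccc(Oc4ccccc4)cc3)cc2C(=O)OCC)C1`, 44000 nM; compound 2 `C=CC(=O)Nc1cccc(Cn2nc(-c3ccc(Oc4ccccc4)cc3)cc2CO)c1`, 6000 nM; compound 3 `CCOC(=O)c1cc(-c2ccc(Oc3ccccc3)cc2)nn1C1CCCN(C(=O)CCl)C1`, 1300 nM.

Compound 1 and compound 3 differ in one place: chloromethyl in place of vinyl on a carbonyl carbon. This change gave a 34-fold lower number from compound 1 to compound 3 (1.53 log units; beyond the scatter). Compound 4 `O=C(CCl)Nc1cccc(Cn2nc(-c3ccc(Oc4ccccc4)cc3)cc2CO)c1` is not yet measured and stands to compound 2 as compound 3 stands to compound 1: chloromethyl in place of vinyl on a carbonyl carbon. The cores of compound 1 and compound 2 differ, but that difference is not broken down here. The two places are not the same word for word: in compound 1 the other neighbour of the carbonyl carbon is an amide-type nitrogen in a ring, in compound 2 an amide-type nitrogen, so the change is the same kind of change, not the same. Going by the values given here, compound 2 and compound 3 differ in more than one place; their values show only that compound 3 gives the lower number.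

For compound 4 a lower number than compound 2 is expected, an estimated step of a 10-fold lower number from compound 2 to compound 4 (1.00 log units; beyond the scatter), which rests on the measured step of a 34-fold lower number from compound 1 to compound 3 (1.53 log units; beyond the scatter). Among the compounds with values here, the place differs and only one such step is known, so the expected step is kept smaller. The estimate for compound 4 in this assay is 600 nM, with a range from 150 nM to 3000 nM.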

Compound 4, half-maximal inhibitory concentration: 400 nM
Compound 4: middle estimate off by 1.5-fold (0.18 log units), on the high side; measured number inside the range.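

In this assay chloromethyl in place of vinyl on a carbonyl carbon gave a 15-fold lower number from compound 2 to compound 4 (1.18 log units; beyond the scatter) and so lowered the number on a second core, as it had on the core of compound 1. This shows that the change carried over between these two cores, but two pairs of compounds make no rule for the whole series and do not explain why the number falls. The two steps can be treated as the same size: the same change on two cores in this assay, a 34-fold lower number (1.53 log units; beyond the scatter) from compound 1 to compound 3 and a 15-fold lower number (1.18 log units; beyond the scatter) from compound 2 to compound 4, 2.3-fold (0.35 log units) apart, within the scatter of two such steps

Still open, on these data alone, is how bromomethyl or a longer chain such as chloroethyl would compare with chloromethyl on that carbonyl carbon. Also open, as far as these compounds go, is whether the step holds on cores other than these two.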